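Side-chain step from compound 1 to compound 4

The source may hold more compounds than are shown below. What is called first, only, known or untested is meant among the compounds shown, and "the series" means these compounds.

Measured in a functional assay on HL-60 cells (Homo sapiens) for antiproliferative activity, read by MTT assay, with a stated time of 72 h; on this read-out higher numbers stand for weaker inhibition and lower numbers for stronger inhibition:
- compound 1 `COc1cc(C(=O)c2ccc(-c3csc(NC(=O)CN)n3)cc2-n2cncn2)cc(OC)c1OC`: 27 nM
- compound 2 `COc1cc(C(=O)c2ccc(-c3csc(NC(=O)C(C)(C)N)n3)cc2-n2cncn2)cc(OC)c1OC`: 5 nM
- compound 3 `COc1cc(C(=O)c2ccc(-c3csc(NC(=O)[C@@H](N)CC(C)C)n3)cc2-n2cncn2)cc(OC)c1OC`: 76 nM

Compound 1 stands second highest of these three numbers, with compound 3 higher and compound 2 lower. The next candidate is compound 4 `COc1cc(C(=O)c2ccc(-c3csc(NC(=O)[C@@H](N)CC4CCCCC4)n3)cc2-n2cncn2)cc(OC)c1OC`, not yet measured in this assay. Its change from the core of compound 1 is cyclohexylmethyl in place of hydrogen on a saturated chain carbon bound to an amine nitrogen and a carbonyl carbon.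

The closest guide is isobutyl in place of that hydrogen, a modest step: a 2.8-fold higher number from compound 1 to compound 3 (0.45 log units; beyond the scatter). Compound 2 goes against any single direction for substitution on this carbon, with a modest step the other way: a 5.4-fold lower number from compound 1 to compound 2 (0.73 log units; beyond the scatter). The gap between those two compounds is large: a 15-fold higher number from compound 2 to compound 3 (1.18 log units; beyond the scatter). A modest step towards a higher number is therefore expected, following the isobutyl case. The estimated step is a 3.7-fold higher number from compound 1 to compound 4 (0.57 log units; beyond the scatter). For compound 4 the estimated value is 100 nM, with an expected range of 35 nM to 280 nM.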

Compound 4, half-maximal inhibitory concentration: 86 nM
Compound 4: middle estimate off by 1.2-fold (0.07 log units), on the high side; the measured number falls inside the stated range.
By their numbers in this assay, from the lowest: compound 2; then compound 1; then compounds 3 and 4 (each within the scatter of the next).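

In this assay cyclohexylmethyl on the saturated chain carbon bound to an amine nitrogen and a carbonyl carbon gives a 3.2-fold higher number from compound 1 to compound 4 (0.50 log units; beyond the scatter) and so falls on the same side as the isobutyl group of compound 3. Cyclohexyl in place of isopropyl further out on the chain gives a 1.1-fold higher number from compound 3 to compound 4 (0.05 log units; within the scatter) and does not separate these two side chains in this assay. Compound 2 remains the exception to this direction among substituted compounds, with a 17-fold higher number from compound 2 to compound 4 (1.24 log units; beyond the scatter) as its gap to the new compound.

Open, from the compounds shown here alone, is how a single methyl on this carbon would read against the two methyl groups of compound 2. Also open, going by these compounds, is whether a phenyl ring, a carboxylic acid or a longer chain would keep the number of compounds 3 and 4. No measurement shown here bears on the reason for these steps.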